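The source may report more compounds than this note shows. Statements on the series, on what has been measured and on what is new or still open speak of the compounds shown alone.

Measured so far in an ADME assay on HEK-293T cells (Homo sapiens) for cytotoxicity, read by resazurin assay, with a stated time of 16 h; a higher number here means a weaker inhibitor, a lower number a stronger inhibitor
- compound 1 `OC[C@H]1O[C@@H](n2cnc3c(NC4CCCC4)nc(NC4CCCCCC4)nc32)[C@H](O)[C@@H]1O` gives 167000 nM as its value
- compound 2 `OC[C@H]1O[C@@H](n2cnc3c(NCCC(c4ccccc4)c4ccccc4)nc(NCc4cccc5ccccc45)nc32)[C@H](O)[C@@H]1O` is recorded as "not determined" (no result reported)
- compound 3 `OC[C@H]1O[C@@H](n2cnc3c(N4CCCCC4)nc(NC4CCCC4)nc32)[C@H](O)[C@@H]1O` is recorded as "not determined" (no result reported)

Within the data shown here, compound 1 carries the only number, so it can be ranked against nothing and serves only as a single reference point. Compound 4 `OC[C@H]1O[C@@H](n2cnc3c(NC4CCCC4)nc(NC4CCCCC4)nc32)[C@H](O)[C@@H]1O` has cyclohexyl in place of cycloheptyl on a nitrogen on an aromatic ring, the difference being cyclohexyl in place of cycloheptyl on a nitrogen on an aromatic ring with the rest of the structure unchanged. Among the measured compounds shown here, no measured pair shows what a change of this kind does in this assay, so the data offer no direct guide to its size or direction. For the measured compounds named here, with only this ring change and no measured step pointing either way, no shift beyond the scatter is expected, and the expectation stays anchored on compound 1 at 167000 nM in this series. The expected change is a 1.1-fold higher number from compound 1 to compound 4 (0.03 log units; within the scatter) and its direction is left open. For compound 4 the estimated value is 180000 nM with an expected range from 90000 nM to 350000 nM in this assay.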

Compound 4, half-maximal inhibitory concentration: 228000 nM
The estimate for compound 4 lay 1.3-fold (0.10 log units) below the measured number, and the stated range covers the measured number.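

In this assay, among these compounds, cyclohexyl in place of cycloheptyl on a nitrogen on an aromatic ring gives a 1.4-fold higher number from compound 1 to compound 4 (0.14 log units; within the scatter), the first step that can be read. At this position, therefore, the seven-membered and six-membered carbon rings cannot be told apart in this read-out, though this rests on a single pair. The available data offer no explanation of this result, and none is assigned to the ring change.

As far as these compounds go, whether this insensitivity extends beyond these two rings remains open: an amine, a carboxylic acid or a longer chain in place of cyclohexyl on the same nitrogen could give a different outcome. Compound 2 and compound 3 carry no number, so neither can test this reading.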